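The source may hold more compounds than are shown below. What is called first, only, known or untested is meant among the compounds shown, and "the series" means these compounds.

Measured so far in a functional assay on A549 cells (Homo sapiens) for inhibition; on this read-out lower numbers stand for stronger inhibition and higher numbers for weaker inhibition:
Compound 1 `CC(C)c1cc(-c2n[nH]c(=O)n2-c2ccc(C(=O)NCCCCCCC(=O)NO)cc2)c(O)cc1O` gives 4600 nM.
Compound 2 `CC(C)c1cc(-c2n[nH]c(=O)n2-c2ccc(C(=O)NCCCCCCCC(=O)NO)cc2)c(O)cc1O` gives 4600 nM.
Compound 3 `CC(C)c1cc(-c2n[nH]c(=O)n2-c2ccc(C(=O)NCCCCCC(=O)NO)cc2)c(O)cc1O` gives 4600 nM.

These three share one core and differ only in the length of the saturated chain carrying the hydroxycarbamoyl group. Compound 3 stands level with compounds 1 and 2 in this assay; no one of the three is set apart from the others. Compound 4 `CC(C)c1cc(-c2n[nH]c(=O)n2-c2ccc(C(=O)NCCCCC(=O)NO)cc2)c(O)cc1O` shortens that chain once more: hydroxycarbamoyl in place of (hydroxycarbamoyl)methyl on a saturated chain carbon, four bonds along the chain from an amide-type nitrogen. The steps already seen that bear on this, no change at the digits printed from compound 1 to compound 3 (within the scatter) and no change at the digits printed from compound 2 to compound 3 (within the scatter), together with no change at the digits printed from compound 1 to compound 2 (within the scatter), all stayed within the scatter, so changing the chain length has so far left the read-out unmoved. Compound 4 is therefore expected to show a 1.2-fold higher number from compound 3 to compound 4 (0.08 log units; within the scatter). Compound 4 is estimated at 5500 nM, expected to fall between 2500 nM and 15000 nM.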

Compound 4, half-maximal inhibitory concentration: 4600 nM
Beside the measured number, compound 4's estimate is 1.2-fold (0.08 log units) above it; the range from low to high includes it.
By their numbers in this assay, from the lowest: compounds 1, 2, 3 and 4 (each within the scatter of the next).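

Shortening the chain once more, so that hydroxycarbamoyl sits four bonds along the chain from an amide-type nitrogen, still leaves this assay unmoved: there is no change at the digits printed from compound 3 to compound 4 (within the scatter), no change at the digits printed from compound 2 to compound 4 (within the scatter) and no change at the digits printed from compound 1 to compound 4 (within the scatter). Among these compounds, the flat read-out now holds across all four chain lengths, with no compound going against it. A larger shortening also reads alike from two different starting chains: the same change on two cores in this assay, no change at the digits printed (within the scatter) from compound 2 to compound 3 and no change at the digits printed (within the scatter) from compound 1 to compound 4, 1.0-fold (0.00 log units) apart, within the scatter of two such steps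

From the compounds shown here alone, whether a still shorter or longer chain would move the number remains open. So does whether a carboxylic acid in place of hydroxycarbamoyl would change it, which leaves the contribution of that group itself untested.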